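Amide-side aryl swap in an azo-indole series

This account rests on a few compounds, and the source may have more. Where it says the series, first, only, none or still open, it means among the compounds named here.

Compound 3 `Cc1ccc(C)c(NC(=O)c2ccc(/N=N\c3c[nH]c4ccccc34)cc2)c1` is recorded in a functional assay on P388 cells (Mus musculus) for inhibition, read by MTT assay, with a stated time of 72 h (on this read-out higher numbers stand for weaker inhibition and lower numbers for stronger inhibition), only as "not active" (no number reported), with no number, so its position on the scale cannot be fixed. Among the compounds with values here, compound 1 `Cc1ccc(NC(=O)c2ccc(/N=N\c3c[nH]c4ccccc34)cc2)cc1` gives 300 nM in this assay, and compound 2 `O=C(Nc1ccccc1[N+](=O)[O-])c1ccc(/N=N\c2c[nH]c3ccccc23)cc1` gives 77900 nM; the single measured step, a 260-fold higher number from compound 1 to compound 2 (2.41 log units; beyond the scatter), shows how strongly the aryl on the amide nitrogen moves the read-out. Compound 4 `Cc1ccc(NC(=O)c2ccc(/N=N\c3c[nH]c4ccccc34)cc2)c(C)c1` differs from compound 3 by 2,4-dimethylphenyl in place of 2,5-dimethylphenyl on an amide-type nitrogen. Within the data shown here, no measured step matches this change; the only guidance is that compound 1 carries a 4-methylphenyl and is potent, whereas compound 3 carries a 2,5-dimethylphenyl and registers no activity, and compound 4 shares a feature of each. The direction relative to compound 3 cannot be read from the data, and a weak result remains plausible. Compound 4 is therefore estimated at 20000 nM in this assay, with an expected range of 1500 nM to 200000 nM, and a real chance that again only inactivity is reported.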

Compound 4, half-maximal inhibitory concentration: 190000 nM
Compound 4: middle estimate off by 9.5-fold (0.98 log units), on the low side, within the range that was stated.
By their numbers in this assay, from the lowest: compound 1; then compound 2; then compound 4.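

In this assay a single added methyl on an aromatic carbon of the amide-side aryl gives a 630-fold higher number from compound 1 to compound 4 (2.80 log units; beyond the scatter) and so removes almost all of the inhibition seen with the 4-methylphenyl, showing that even this small change at the position is not tolerated. The swap of 2-nitrophenyl for 2,4-dimethylphenyl gives a 2.4-fold higher number from compound 2 to compound 4 (0.39 log units; beyond the scatter) and shows that an aryl without a nitro group can also sit at the weak end of the series. No measurement shown here accounts for either step.

Compound 3 has no number, so the change from 2,5-dimethylphenyl to 2,4-dimethylphenyl cannot be read as a step. Open too, from the compounds shown here alone, is whether a 2-methylphenyl alone, or a methoxy or a chlorine in place of the added methyl, would bring the same loss.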